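A few compounds are considered here, and "the series" means these few. Any claim that something is new, unique, unknown or untested is made for them only; others in the source may bear on it.

Compound 2, whose structure is `CCn1c(CNc2ccccc2)nnc1SCC(=O)Nc1ccc(C(=O)OC(C)(C)C)cc1`, is measured in an assay on isolated protein for inhibition of long-chain fatty acid transport protein 1 (Homo sapiens) (a higher number here means a weaker inhibitor, a lower number a stronger inhibitor), only as a limit, > 1000 nM, and not as a number. Its parent compound 1, with the structure `CCn1c(CNc2ccccc2)nnc1SCC(=O)Nc1ccc(C(=O)OC)cc1`, gives 540 nM in this assay. Going by the values given here, the single measured step, an at least 1.8-fold higher number from compound 1 to compound 2 (0.26 log units; that floor lies within the scatter), moves the tert-butyl ester from a number to the limit of > 1000 nM in this assay, at which 1 of the 2 values shown sits, so the size of that step is not fixed. Compound 3, with the structure `CCn1c(CNc2ccccc2)nnc1SCC(=O)Nc1ccc(OC)cc1`, differs from compound 2 by methoxy in place of tert-butoxycarbonyl on an aromatic carbon. Among the compounds with values here, no measured step exchanges the ester for an ether, so the expectation for compound 3 rests only on compound 1 and the limit of compound 2 and is loose. Compound 3 is estimated at 800 nM in this assay, between 300 nM and 3000 nM, which as a step means an at least 1.2-fold lower number from compound 2 to compound 3 (0.09 log units; that floor lies within the scatter) and is expected to fall within the scatter.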

Compound 3, half-maximal inhibitory concentration: > 1000 nM
Compound 3 ended at the assay's limit; the forecaster's own chance of this, stated with the estimate: 40%; middle value at least 1.2-fold (0.09 log units) away from the limit.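

In this assay, methoxy is a second replacement on this aromatic carbon, one that leaves no carbonyl there, and compound 3 gives > 1000 nM, which is again a limit and not a number. The exchange of the methyl ester for the ether is an at least 1.8-fold higher number from compound 1 to compound 3 (0.26 log units; that floor lies within the scatter), so a real loss against the parent is not established and its size stays unfixed. The step between compound 2 and compound 3 cannot be read, and compound 1 alone now carries a number: the limit of > 1000 nM in this assay, at which 2 of the 3 values shown sit.

On these data alone, how far compound 2 and compound 3 really lie from compound 1 remains open. Also open, as far as these compounds go, is whether a carboxylic acid or an amine on this aromatic carbon would give a readable number, and how that number would compare with compound 1 at 540 nM.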